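Adding a second chloro to compound 2's core

The source may hold more compounds than are shown below. What is called first, only, known or untested is meant among the compounds shown, and "the series" means these compounds.

Measured compounds:
`ClCc1cccc(Cn2cnc3c(Cl)nc(Cl)nc32)c1` compound 1, 40700 nM
`ClCc1ccccc1Cn1cnc2ncnc(Cl)c21` compound 2, 12000 nM

In a functional assay on SF-539 cells (Homo sapiens) for cytotoxicity, read by sulforhodamine B assay, with a stated time of 48 h (a lower number here means that less compound is tolerated, a higher number that more compound is tolerated), compound 2 gives 12000 nM, the lowest of the two numbers; compound 1 gives 40700 nM, a higher number that lies beyond the scatter. The two differ in more than one place, so no single step can be read from them. Compound 3 `ClCc1ccccc1Cn1cnc2nc(Cl)nc(Cl)c21` arises from compound 2 by chloro in place of hydrogen on an aromatic carbon. Within the data shown here, with no measured step of this kind, only a modest rise in the number is expected, and the expected step of a 1.7-fold higher number from compound 2 to compound 3 (0.22 log units; within the scatter) stays close to the scatter. For compound 3 the estimate is 20000 nM, with a range from 8000 nM to 50000 nM.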

Compound 3, concentration lethal to 50% of the cells: 8310 nM
Compound 3: middle estimate off by 2.4-fold (0.38 log units), on the high side, within the range that was stated.
By their numbers in this assay, from the lowest: compounds 3 and 2 (each within the scatter of the next); then compound 1.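

In this assay chloro in place of hydrogen on this aromatic carbon, between two ring nitrogen atoms, gives a 1.4-fold lower number from compound 2 to compound 3 (0.16 log units; within the scatter) and so leaves the two compounds within the scatter of each other. This is the first step in one place among these compounds, and it shows that adding this chloro brings no change that can be told from the scatter. No measurement shown explains this result. From the compounds shown here alone, whether an amine or a methoxy group at this position would also leave the number within the scatter stays open. So does the effect of replacing the chloromethyl group with a longer chain.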